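Swapping a Methoxyphenyl for a Chlorophenyl on Cytotoxicity

A few compounds are considered here, and "the series" means these few. Any claim that something is new, unique, unknown or untested is made for them only; others in the source may bear on it.

Compound 1 `COc1cccc(-c2nc3c(c(C)nn3-c3ccccc3)c(-c3ccccc3O)c2C#N)c1`: > 23000 nM
Compound 2 `CCc1ccc(-c2nc3c(c(C)nn3-c3ccccc3)c(-c3cccc(O)c3)c2C#N)cc1`: > 20000 nM

Both readings come from an ADME assay on BJ cells (Homo sapiens) for cytotoxicity, with a stated time of 72 h; on this read-out higher numbers stand for an effect only at larger amounts of compound and lower numbers for an effect already at smaller amounts. For compound 1 the reading > 23000 nM is a limit of the assay, not a number. For compound 2 the reading > 20000 nM is likewise only a limit. Compound 1 therefore stands at the limit, with no number to place it against compound 2. Compound 3 `Cc1nn(-c2ccccc2)c2nc(-c3ccc(Cl)cc3)c(C#N)c(-c3ccccc3O)c12` differs from compound 1 by 4-chlorophenyl in place of 3-methoxyphenyl on an aromatic carbon. Going by the values given here, no measured step guides this change, so in this assay the expected step that the limit leaves unreadable from compound 1 to compound 3 is none beyond the scatter. Compound 3 is expected to give 25000 nM, in the range 10000 nM to 60000 nM.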

Compound 3, half-maximal effective concentration: > 20000 nM
Compound 3: a limit, no number (the forecaster's own chance of this, stated with the estimate: 80%); the middle value does not contradict the limit.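

Going by these compounds alone, compound 1 and compound 3 both give only limits in this assay, so no step between them can be read. The compounds shown leave open whether 4-chlorophenyl in place of 3-methoxyphenyl changes the amount needed for an effect.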